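This account rests on a few compounds, and the source may have more. Where it says the series, first, only, none or still open, it means among the compounds named here.

Two closely related compounds have been measured so far. Compound 1 `CCNC(=O)[C@H]1O[C@@H](n2cnc3c(NNC(=O)c4ccc(Br)o4)ncnc32)[C@H](O)[C@@H]1O` gives 780 nM in an assay on CHO cells for displacement of a labelled ligand from adenosine receptor A1 (Homo sapiens); on this read-out lower numbers stand for stronger inhibition and higher numbers for weaker inhibition. Compound 2 `CCNC(=O)[C@H]1O[C@@H](n2cnc3c(NNC(=O)c4cccs4)nc(Cl)nc32)[C@H](O)[C@@H]1O` gives 737 nM in this assay. Compound 2 carries the lowest of the two numbers shown, but its gap to compound 1 lies within the scatter, so the two values cannot be told apart and neither compound can be called the stronger binder.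

Compound 3 `CCNC(=O)[C@H]1O[C@@H](n2cnc3c(NNC(=O)c4cc(C)on4)nc(Cl)nc32)[C@H](O)[C@@H]1O` has not yet been measured. It differs from compound 2 in one place: 5-methyl-1,2-oxazol-3-yl in place of thiophen-2-yl on a carbonyl carbon. Among the compounds with values here, no pair of measured compounds shows a change of this kind, so no measured step can guide the expectation. The shared core and the amide-bearing side are unchanged, and only the aromatic ring on the carbonyl carbon is swapped. On that basis the step is expected to be small, most likely a modest weakening or none beyond the scatter, and the estimate for compound 3 rests mainly on the value of compound 2. The expected step is a 1.3-fold higher number from compound 2 to compound 3 (0.11 log units; within the scatter). Compound 3 is therefore estimated at 950 nM, with a range from 350 nM to 2600 nM.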

Compound 3, inhibition constant: > 5000 nM
Compound 3 ended at the assay's limit; the forecaster's own chance of this, stated with the estimate: 5%; middle value at least 5.2-fold (0.72 log units) from the limit.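

The aromatic ring on this carbonyl carbon turns out not to be a neutral place in this assay: with the shared core and everything else held constant, 5-methyl-1,2-oxazol-3-yl in place of thiophen-2-yl gives an at least 6.7-fold higher number from compound 2 to compound 3 (0.83 log units; beyond the scatter). Compound 3 reads > 5000 nM, which is a limit of the assay and not a number. Compounds 1 and 2 differ in more than one place and could not show how much this single change matters, and the new step gives only a lower bound on its size because the value sits at that limit: the limit of > 5000 nM in this assay, at which 1 of the 3 values shown sits.

The entering ring differs from thiophen-2-yl in its hetero atoms and also in carrying a methyl group, and the compounds shown do not tell which of these two differences goes with the step. On these data alone, how a 1,2-oxazol-3-yl ring without the methyl, or a plain phenyl ring, would read on this carbonyl carbon stays open, as does how far past the limit compound 3 really lies.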